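The source may report more compounds than this note shows. Statements on the series, on what has been measured and on what is new or still open speak of the compounds shown alone.

Compound 1 `CSc1nc(SC)c2ncn([C@@H]3C[C@@H](O)[C@H](CO)O3)c2n1` carries two methylsulfanyl groups on the shared core. In a functional assay on K562 cells (Homo sapiens) (on this read-out lower numbers stand for stronger inhibition and higher numbers for weaker inhibition), compound 1 returns a limit, > 300 uM, and not a number. That is the limit of the method, (the limit of > 300 uM in this assay, at which 1 of the 3 values shown sits), so compound 1 sits at the weak end of what this assay can resolve. Compounds 2 and 3 share the core but carry a bromine and an amino group rather than the two methylsulfanyl groups: compound 2 `Nc1nc(Br)nc2c1ncn2[C@@H]1C[C@@H](O)[C@H](CO)O1` gives 83 uM in this assay, and compound 3 `CNc1nc(Br)nc2c1ncn2[C@@H]1C[C@@H](O)[C@H](CO)O1` gives 110 uM. The step of a 1.3-fold higher number from compound 2 to compound 3 (0.12 log units; within the scatter) says that a methyl on that nitrogen leaves the read-out where it was.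

Compound 4 `CSc1nc(N(C)C)c2ncn([C@@H]3C[C@@H](O)[C@H](CO)O3)c2n1` differs from compound 1 by dimethylamino in place of methylsulfanyl on an aromatic carbon. For the measured compounds named here, no measured step covers this exchange; the one step known concerns methyl on a nitrogen and stays within scatter. Compounds 2 and 3 show that an amino group on that carbon, with a bromine elsewhere, gives a number below the limit, but they differ from compound 4 in two places. Compound 4 is therefore expected near 250 uM, within 70 uM to 900 uM. The expected step of an at least 1.2-fold lower number from compound 1 to compound 4 (0.07 log units; that floor lies within the scatter) is small, and a limit again is a real possibility.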

Compound 4, concentration for 50% inhibition: > 300 uM
Compound 4: no number, only a limit; the forecaster's own chance of this, stated with the estimate: 45%; at least 1.2-fold (0.07 log units) between middle value and limit.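

Compound 1 and compound 4 both return only a limit and not a number, so the step between them cannot be read: the limit of > 300 uM in this assay, at which 2 of the 4 values shown sit.

Still open, going by these compounds, is whether dimethylamino in place of methylsulfanyl on an aromatic carbon shifts the read-out in this assay at all.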